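Trimethoxyphenyl pyrazole chalcones: dropping one methoxy group

The source may report more compounds than this note shows. Statements on the series, on what has been measured and on what is new or still open speak of the compounds shown alone.

Measured so far:
compound 1, `COc1cc(-c2cc(/C=C/C(=O)c3ccc(N)cc3)[nH]n2)cc(OC)c1OC`: -21%
compound 2, `COc1cc(-c2cc(/C=C/C(=O)c3ccc(Cl)c(Cl)c3)[nH]n2)cc(OC)c1OC`: -15%

Both measured compounds were tested in a functional assay on CCRF-CEM cells (Homo sapiens) for cytotoxicity, read by sulforhodamine B assay, with a stated time of 48 h, tested at 100 uM; on this read-out higher numbers stand for a weaker effect at the one concentration tested and lower numbers for a stronger effect. Compound 1 gives -21% and compound 2 gives -15%; the two numbers sit within the usual scatter of each other, so neither is set apart from the other on this read-out. For the measured compounds named here, the one measured step, a number 6 percentage points higher from compound 1 to compound 2 (within the scatter), exchanges the aryl group on the carbonyl carbon and leaves the shared core untouched.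

Compound 3, `COc1ccc(-c2cc(/C=C/C(=O)c3ccc(N)cc3)[nH]n2)cc1OC`, is not yet measured. It differs from compound 1 as follows: hydrogen in place of methoxy on an aromatic carbon.

Going by the values given here, no measured step touches a methoxy group on the shared core, so there is no direct precedent for this change. Among the compounds with values here, both numbers so far lie in a narrow band, and the only known step is within the scatter. Compound 3 is therefore expected to stay near compound 1, with the step of a number 6 percentage points higher from compound 1 to compound 3 (within the scatter) expected to be within the scatter. The estimate for compound 3 is -15%, with a range from -40% to 10%.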

Compound 3, a percentage reported as activity, at one concentration (the size of the read-out at that concentration, not a potency): -22%
Compound 3: the middle estimate sits 7 percentage points above what was measured; the range from low to high includes it.
By their numbers in this assay, from the lowest: compounds 3, 1 and 2 (each within the scatter of the next).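

Hydrogen in place of methoxy on an aromatic carbon, ortho to a methoxy group and meta to a large group, gives in this assay a step of a number 1 percentage points lower from compound 1 to compound 3 (within the scatter). This is the first step shown on the shared core rather than on the aryl group on the carbonyl carbon, and it shows that a methoxy group of 2 heavy atoms can leave this place with no change beyond the scatter on this read-out. No measured data on the series offer an account of this result.

All readings come from one high concentration, so they leave open whether the two compounds would part at lower concentrations. Also open, on these data alone, is how a hydroxyl or an ethoxy group at this same place would read, and whether the remaining methoxy groups can go as well.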